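Amide aryl swap on the shared core: compound 3 to compound 4

The source may report more compounds than this note shows. Statements on the series, on what has been measured and on what is new or still open speak of the compounds shown alone.

Measured in an assay on cells with melanin-concentrating hormone receptor 1 (Homo sapiens) as the target, read by radioligand binding; on this read-out higher numbers stand for weaker inhibition and lower numbers for stronger inhibition:
- compound 1, `CC(CNC1CCCC1)Oc1cccc2ccc(N)nc12`: compound 1 gives 30 nM
- compound 2, `CC(CNc1ccc2[nH]ncc2c1)Oc1cccc2ccc(N)nc12`: compound 2 gives 530 nM
- compound 3, `CC(C)c1ccc(C(=O)NCCCOc2cccc3ccc(N)nc23)cc1`: compound 3 gives 60 nM

Compound 3 has the second highest of the three numbers. Its nearest neighbour is compound 1, whose number is lower but within the scatter, so no order between the two is claimed. Compound 2 is furthest away, with a higher number beyond the scatter.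

Compound 4, `Nc1ccc2cccc(OCCCNC(=O)c3cccc(Cl)c3)c2n1`, is not yet measured. It differs from compound 3 in one place: 3-chlorophenyl in place of 4-isopropylphenyl on a carbonyl carbon. Going by the values given here, no pair among the measured compounds shows this change, so nothing measured tells the size of the step.

The amide linker and the shared core are untouched; only the aryl on the carbonyl carbon changes. A modest step is expected, if any, towards a somewhat higher number, and it may well stay within the scatter. Compound 4 is expected at 100 nM, range 30 nM to 350 nM. This estimate means a step of a 1.7-fold higher number from compound 3 to compound 4 (0.22 log units; within the scatter), expected and not measured.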

Compound 4, half-maximal inhibitory concentration: 0.4 nM
Compound 4: middle estimate off by 250-fold (2.40 log units), on the high side; the whole stated range lies above it.
By their numbers in this assay, from the lowest: compound 4; then compounds 1 and 3 (each within the scatter of the next); then compound 2.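

In this assay, the aryl on the carbonyl carbon emerges as a highly sensitive position: 3-chlorophenyl in place of 4-isopropylphenyl gives a 150-fold lower number from compound 3 to compound 4 (2.18 log units; beyond the scatter), with the amide linker and the shared core untouched. Going by these compounds alone, the earlier compounds included no pair differing in one place, so this is the first step that can be read, and it shows that a single aryl swap on this amide can carry a large change by itself. Nothing measured here accounts for the size of this step.

As far as these compounds go, whether the step comes from the incoming chlorine or from the loss of the isopropyl remains open, and plain phenyl on the same carbonyl carbon would separate the two. Also open, from the compounds shown here alone, is how a pyridyl ring would behave in this place.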